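Swapping the Aryl Group on a Sulfonamide Growth Inhibitor

The source may hold more compounds than are shown below. What is called first, only, known or untested is meant among the compounds shown, and "the series" means these compounds.

Measured compounds and their results in a functional assay on ASPC1 cells (Homo sapiens) for inhibition, read by MTT assay, with a stated time of 72 h; on this read-out lower numbers stand for stronger inhibition of growth and higher numbers for weaker inhibition of growth:
compound 1, `O=S(=O)(NCCCNCc1cccc2ccccc12)c1cc(C(F)(F)F)cc(C(F)(F)F)c1`, gives 21000 nM
compound 2, `CC(C)(C)c1ccc(CNCCNS(=O)(=O)c2cc(C(F)(F)F)cc(C(F)(F)F)c2)cc1`, gives 14000 nM
compound 3, `COc1cccc(CNCCCNS(=O)(=O)c2cc(C(F)(F)F)cc(C(F)(F)F)c2)c1`, gives 3800 nM

Compound 3 stands lowest of the three numbers in this assay, that is, it is the strongest growth inhibitor of the set; compound 2 is its nearest neighbour and compound 1 the furthest, both beyond the scatter. Going by the values given here, the one step that changes only the aryl group on the saturated chain carbon bound to the amine nitrogen is a 5.5-fold lower number from compound 1 to compound 3 (0.74 log units; beyond the scatter), so this position clearly matters.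

Compound 4, `O=S(=O)(NCCCNCc1ccccc1Cl)c1cc(C(F)(F)F)cc(C(F)(F)F)c1`, has not been measured. It differs from compound 3 as follows: 2-chlorophenyl in place of 3-methoxyphenyl on a saturated chain carbon bound to an amine nitrogen. Among the compounds with values here, no measured step involves 2-chlorophenyl, so the direction cannot be read from the data. The aryl group is known to shift the number noticeably, and the two other aryl groups both gave higher numbers than compound 3, so a moderate rise is expected: the estimated step is a 1.8-fold higher number from compound 3 to compound 4 (0.27 log units; within the scatter). Compound 4 is therefore expected to give about 7000 nM, within roughly 2500 nM to 20000 nM.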

Compound 4, concentration for 50% growth inhibition: 13000 nM
Compound 4: the middle estimate sits 1.9-fold (0.27 log units) below what was measured; measured number inside the range.
By their numbers in this assay, from the lowest: compound 3; then compounds 4, 2 and 1 (each within the scatter of the next).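

In this assay, the new group does not keep the lower number of compound 3: a 3.4-fold higher number from compound 3 to compound 4 (0.53 log units; beyond the scatter). Against the naphthalen-1-yl group, the 2-chlorophenyl group shows no clear difference: a 1.6-fold lower number from compound 1 to compound 4 (0.21 log units; within the scatter). A single aromatic ring is therefore not enough on its own to give the lower number, since compound 3 and compound 4 both carry one, and among these three groups only 3-methoxyphenyl stands apart at this place.

The data shown offer no measurement that explains why these two groups differ. On these data alone, it also remains open whether the lower number of compound 3 goes with the methoxy group itself or with where it sits on the ring, which a 3-chlorophenyl or a 2-methoxyphenyl group at this place could help to separate.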